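A few compounds are considered here, and "the series" means these few. Any claim that something is new, unique, unknown or untested is made for them only; others in the source may bear on it.

Measured so far in a functional assay on HCT-116 cells (Homo sapiens) for antiproliferative activity; on this read-out lower numbers stand for stronger inhibition and higher numbers for weaker inhibition:
compound 1 `NC(=O)c1c(Nc2ccc(I)cc2F)cc(F)cc1Oc1cccc(NS(N)(=O)=O)c1` gives 180 nM;
compound 2 `CCS(=O)(=O)Nc1cccc(Oc2cc(F)c(F)c(Nc3ccc(I)cc3F)c2C(N)=O)c1` gives 65 nM;
compound 3 `CCS(=O)(=O)Nc1cccc(Oc2c(F)c(F)cc(Nc3ccc(I)cc3F)c2C(N)=O)c1` gives 81 nM.

Compound 2 holds the lowest of the three numbers; compound 3 sits within the scatter of it, while compound 1 lies beyond it at the high end. Compound 4 `NC(=O)c1c(Oc2cccc(NS(N)(=O)=O)c2)cc(F)c(F)c1Nc1ccc(I)cc1F` is not yet measured. It keeps the core of compound 2 and carries amino in place of ethyl on a sulfonyl sulfur, read one bond further out as ethylsulfonyl to sulfamoyl. Among the compounds with values here, no measured pair shows this change alone: compound 1 carries the sulfamoyl group on a core fluorinated differently, so it sets no clean step. Still, compound 1 gives 180 nM against compound 2 at 65 nM. The step expected here, a 1.8-fold higher number from compound 2 to compound 4 (0.27 log units; within the scatter), is a modest rise, possibly within the scatter. Compound 4 is estimated at 120 nM, range 50 nM to 300 nM.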

Compound 4, half-maximal inhibitory concentration: 50 nM
The estimate for compound 4 lay 2.4-fold (0.38 log units) above the measured number, and the stated range covers the measured number.
By their numbers in this assay, from the lowest: compounds 4, 2 and 3 (each within the scatter of the next); then compound 1.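

In this assay, amino in place of ethyl on a sulfonyl sulfur gives the first clean read at this position, and the change stays within the scatter (a 1.3-fold lower number from compound 2 to compound 4 (0.11 log units; within the scatter)). With the sulfamoylamino group held constant, fluoro in place of hydrogen on an aromatic carbon gives a step beyond the scatter (a 3.6-fold lower number from compound 1 to compound 4 (0.56 log units; beyond the scatter)). No supporting data explain either step.

From the compounds shown here alone, whether methyl, propyl or dimethylamino on the sulfonyl sulfur would stay in this range remains open. So does whether the fluoro step carries over to compounds with the (ethylsulfonyl)amino group.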